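The source may report more compounds than this note shows. Statements on the series, on what has been measured and on what is new or still open speak of the compounds shown alone.

Measured so far:
- compound 1 `O=C(NCCCCN1CCN(c2ccc(Cl)cc2)CC1)c1ccc(-c2ccsc2)cc1`: 0.837 h
- compound 2 `COc1cccc(N2CCN(CCCCNC(=O)c3ccc(-c4ccsc4)cc3)CC2)c1`: 0.155 h
- compound 3 `O=C(NCCCCN1CCN(c2ccccc2O)CC1)c1ccc(-c2ccsc2)cc1`: 0.157 h

In an ADME assay on microsomes from liver (Rattus norvegicus) for metabolic stability, read by LC-MS, using NADPH (on this read-out higher numbers stand for a longer-lived compound and lower numbers for a shorter-lived compound), compound 3 stands second highest of the three, though its gap to compound 2 is within the scatter, while compound 1 sits well above both. Compound 4 `Cc1ccc(N2CCN(CCCCNC(=O)c3ccc(-c4ccsc4)cc3)CC2)cc1` differs from compound 3 in one place: 4-methylphenyl in place of 2-hydroxyphenyl on an amine nitrogen in a ring. The step that bears most on this is a 5.3-fold lower number from compound 1 to compound 3 (0.73 log units; beyond the scatter), which is reversed here in the sense that the hydroxyl-bearing ring leaves again; a 5.4-fold lower number from compound 1 to compound 2 (0.73 log units; beyond the scatter) points the same way, and a 1.0-fold higher number from compound 2 to compound 3 (0.01 log units; within the scatter) shows the two lower compounds are alike. A rise beyond the scatter is therefore expected, of about a 2.9-fold higher number from compound 3 to compound 4 (0.46 log units; beyond the scatter). Compound 4 is expected to give 0.45 h, with a range from 0.18 h to 1.1 h.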

Compound 4, half-life: 0.125 h
Compound 4: the middle estimate sits 3.6-fold (0.56 log units) above what was measured; measured number below the stated range.
By their numbers in this assay, from the lowest: compounds 4, 2 and 3 (each within the scatter of the next); then compound 1.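

In this assay, 4-methylphenyl on the ring nitrogen gives a number alike to those of 2-hydroxyphenyl (a 1.3-fold lower number from compound 3 to compound 4 (0.10 log units; within the scatter)) and 3-methoxyphenyl (a 1.2-fold lower number from compound 2 to compound 4 (0.09 log units; within the scatter)), so losing the hydroxyl group does not by itself bring the half-life back up. The sharpest contrast is now a single atom swap on the aromatic carbon, methyl in place of chloro (a 6.7-fold lower number from compound 1 to compound 4 (0.83 log units; beyond the scatter)), and among these four compounds only the 4-chlorophenyl group stands apart. Nothing measured here explains this.

Still open, as far as these compounds go, is whether fluoro or bromo on that same aromatic carbon would behave like chloro or like methyl. A nitrile there would test the same question with a group that holds no halogen.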